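The compounds below may be only part of what the source reports. "The series", "measured", "known", "first", "only" and "open" are said of these compounds alone.

Compound 1 `CCCCCCCC/C=C\CCCCCCCC(=O)OC[C@@H](C)OP(=O)(O)OC[C@H](N)C(=O)O` and compound 2 `CCCCCCCC/C=C\CCCCCCCC(=O)OC[C@@H](COC)OP(=O)(O)OC[C@H](N)C(=O)O` form one pair, compound 3 `C[C@H](COC(=O)CCc1ccccc1OCc1cccc(Oc2ccccc2)c1)OP(=O)(O)OC[C@H](N)C(=O)O` and compound 4 `COC[C@H](COC(=O)CCc1ccccc1OCc1cccc(Oc2ccccc2)c1)OP(=O)(O)OC[C@H](N)C(=O)O` another. How the core of compound 3 differs from the core of compound 1 is not broken down here. In an assay on HEK293 cells for agonist activity at probable G-protein coupled receptor 34 (Mus musculus), with a stated time of 1 h (a lower number here means a smaller maximal response, a higher number a larger maximal response), compound 1 gives 12.8%, compound 2 gives 12.9%, and compound 3 gives 12.4%; all three lie within the usual scatter of one another. The change from compound 1 to compound 2 is methoxy in place of hydrogen on a saturated chain carbon, two bonds along the chain from an oxygen on an unsaturated carbon, and it produced a number 0.1 percentage points higher from compound 1 to compound 2 (within the scatter). The same change, (methoxy in place of hydrogen on a saturated chain carbon, two bonds along the chain from an oxygen on an unsaturated carbon), turns compound 3 into compound 4, at a place described in the same words. Because that earlier step was a number 0.1 percentage points higher from compound 1 to compound 2 (within the scatter), a step of similar size is expected here. The expected step is a number 0.1 percentage points higher from compound 3 to compound 4 (within the scatter). Compound 4 is thus expected to give 12.5%, somewhere between 8% and 18%.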

Compound 4, largest response reached (Emax), in percent of the reference or control that the assay uses: 13.5%
Beside the measured number, compound 4's estimate is 1 percentage points below it; the measured number falls inside the stated range.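

In this assay, methoxy in place of hydrogen gives a number 1.1 percentage points higher from compound 3 to compound 4 (within the scatter). Set beside the earlier step, the change looks the same on both cores: the same change on two cores in this assay, a number 0.1 percentage points higher (within the scatter) from compound 1 to compound 2 and a number 1.1 percentage points higher (within the scatter) from compound 3 to compound 4, 1 percentage points apart, within the scatter of two such steps This shows that the change carried over to the second core without a step beyond the scatter, but with all these numbers so close together, it does not show how the change would behave on a core giving a larger maximal response, and two cores make no general rule.

The compounds shown carry only hydrogen or methoxy at this place, so the effect of a hydroxyl, an ethoxy or an amine there remains open. On these data alone, how much of each compound is needed to reach its response also remains open.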